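The source may report more compounds than this note shows. Statements on the series, on what has been measured and on what is new or still open speak of the compounds shown alone.

Compound 1 `Nc1nn(Cc2cn(-c3ccc(F)c(Cl)c3)nn2)c2nc(-c3ccccc3)cc(C(F)(F)F)c12` gives 99.1 ug/mL in a functional assay on U-937 cells (Homo sapiens) for cytotoxicity, read by MTT assay, with a stated time of 24 h; on this read-out lower numbers stand for stronger inhibition and higher numbers for weaker inhibition.
Compound 2 `Cc1c(Br)cccc1-n1cc(Cn2nc(N)c3c(C(F)(F)F)cc(-c4ccccc4)nc32)nn1` gives 97.2 ug/mL in this assay.
Compound 3 `Cc1ccc(NC(=O)Cn2cc(Cn3nc(N)c4c(C(F)(F)F)cc(-c5ccccc5)nc43)nn2)cc1` gives 65.3 ug/mL in this assay.

Compound 3 shows the lowest of the three numbers, yet the steps leading to it are small: a 1.5-fold lower number from compound 1 to compound 3 (0.18 log units; within the scatter) and a 1.5-fold lower number from compound 2 to compound 3 (0.17 log units; within the scatter), and likewise a 1.0-fold lower number from compound 1 to compound 2 (0.01 log units; within the scatter). All three compounds share one core and differ only in the group on the aromatic nitrogen. Compound 4 `Nc1nn(Cc2cn(CC(=O)Nc3cccc(F)c3)nn2)c2nc(-c3ccccc3)cc(C(F)(F)F)c12` keeps the carbamoylmethyl arm of compound 3 and changes only its far end: 3-fluorophenyl in place of 4-methylphenyl on an amide-type nitrogen. Within the data shown here, no measured step touches this amide-type nitrogen; the nearest evidence is that exchanging the whole arm among compounds 1, 2 and 3 moved nothing beyond the scatter. Compound 4 is therefore expected to stay close to compound 3, with a 1.0-fold lower number from compound 3 to compound 4 (0.00 log units; within the scatter), estimated at 65 ug/mL within 35 ug/mL to 120 ug/mL.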

Compound 4, half-maximal inhibitory concentration: 43.5 ug/mL
For compound 4 the middle estimate is 1.5-fold (0.17 log units) above the measured one, within the range that was stated.
By their numbers in this assay, from the lowest: compounds 4, 3, 2 and 1 (each within the scatter of the next, the first and the last beyond it).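

Exchanging 4-methylphenyl for 3-fluorophenyl on the amide-type nitrogen gives a 1.5-fold lower number from compound 3 to compound 4 (0.18 log units; within the scatter) in this assay so this first change at the far end of the arm does not separate the two compounds. Among these compounds, the whole-arm exchanges now reach past the scatter, though only modestly: a 2.2-fold lower number from compound 2 to compound 4 (0.35 log units; beyond the scatter) and a 2.3-fold lower number from compound 1 to compound 4 (0.36 log units; beyond the scatter) are the first such steps here. Nothing available explains these differences.

The compounds shown leave open what an amine or a carboxylic acid in place of 3-fluorophenyl on the amide-type nitrogen would do. As far as these compounds go, a longer chain in the arm also remains untested in this set.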